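Epimer at the nitrile-bearing ring carbon of compound 2

The compounds below may be only part of what the source reports. "The series", "measured", "known", "first", "only" and "open" are said of these compounds alone.

Within the data shown here, compound 2, `CC(C)(C)[Si](C)(C)OC[C@H]1O[C@@H](n2cnc3c(N)ncnc32)[C@H](O[Si](C)(C)C(C)(C)C)[C@H]1C#N`, is the best-tolerated compound among the numbers so far in a functional assay on cells (Fibroblast, Mus musculus) for cytotoxicity (a lower number here means that less compound is tolerated, a higher number that more compound is tolerated), where compound 2 gives 80 ug/mL. Its nearest neighbour is compound 3, `CC(C)(C)[Si](C)(C)OCC1OC(n2ccc(N)nc2=O)C(O[Si](C)(C)C(C)(C)C)C1C#N`, for which this assay gives 8 ug/mL, a gap beyond the scatter. Compound 1, `CC(=O)Nc1ccn(C2OC(CO[Si](C)(C)C(C)(C)C)C(C#N)C2O[Si](C)(C)C(C)(C)C)c(=O)n1`, is recorded only as a limit of this assay, > 3.2 ug/mL. The step that the limit leaves unreadable from compound 1 to compound 3 is therefore unreadable, and the limit of > 3.2 ug/mL in this assay, at which 1 of the 3 values shown sits, leaves it so.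

Compound 4, `CC(C)(C)[Si](C)(C)OC[C@H]1O[C@@H](n2cnc3c(N)ncnc32)[C@H](O[Si](C)(C)C(C)(C)C)[C@@H]1C#N`, is the compound to be measured. It differs from compound 2 only by the two compounds have the same atoms and bonds and differ only in configuration as drawn: 1 of 4 stereo elements differ; a stereocentre at a saturated ring carbon is drawn S in compound 2 and R in compound 4. Among the measured compounds shown here, none of the measured steps alters configuration at a ring carbon, so no measured step bears directly on this change; the nearest pair, compound 2 against compound 3, concerns a different base, not a stereocentre. With nothing to draw on, the step of no change at the digits printed from compound 2 to compound 4 (within the scatter) is expected to lie within the scatter. For compound 4 the value is estimated at 80 ug/mL, with a range from 30 ug/mL to 160 ug/mL.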

Compound 4, minimum cytotoxic concentration: 8 ug/mL
Compound 4: middle estimate off by 10-fold (1.00 log units), on the high side, outside the stated range (below it).
By their numbers in this assay, from the lowest: compounds 3 and 4 (each within the scatter of the next); then compound 2.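

In this assay the configuration of the stereocentre at a saturated ring carbon turns out to matter on its own, with a 10-fold lower number from compound 2 to compound 4 (1.00 log units; beyond the scatter). No atom or bond changes in this step, so the shift rests on that drawn stereocentre alone: the fact that compounds 2 and 4 differ only in the configuration as drawn. Among these compounds, the only earlier step, hydrogen in place of acetyl on a nitrogen on an aromatic ring, cannot be read and said nothing about configuration.

On these data alone, whether the same inversion carries a step of similar size on the base of compound 3 remains open. Also open, as far as these compounds go, is whether the preference for the configuration of compound 2 holds with a carboxylic acid or a primary amide in place of the nitrile, or with a free hydroxyl in place of a silyl ether.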